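Phenoxy replacement in the weak-inhibitor coumarin-free series notes

The source may report more compounds than this note shows. Statements on the series, on what has been measured and on what is new or still open speak of the compounds shown alone.

Working notes on the series. Compound 1 `Cc1nn(C)c(Oc2ccc(Cl)cc2)c1/C=N\CCCCCOc1cc2oc(=O)cc(C)c2cc1Cl` gives 17500 nM in a functional assay on SMMC-7721 cells (Homo sapiens) for antiproliferative activity, read by MTT assay, with a stated time of 72 h; a higher number here means a weaker inhibitor, a lower number a stronger inhibitor. Compound 2 `Cc1nn(C)c(Oc2ccc(I)cc2)c1/C=N\CCCCCOc1cc2oc(=O)cc(C)c2cc1Cl` returns only a limit of the assay, > 25000 nM, in this assay. The step from compound 1 to compound 2 reads an at least 1.4-fold higher number from compound 1 to compound 2 (0.15 log units; that floor lies within the scatter), iodo in place of chloro on an aromatic carbon. Compound 3 `Cc1nn(C)c(Oc2cccc(F)c2F)c1/C=N\CCCCCCOc1cc2oc(=O)cc(C)c2cc1Cl` gives 22800 nM in this assay, the highest of the two plain numbers; its nearest neighbour, compound 1, sits within the scatter of it, so no order between them is claimed.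

Compound 4 `Cc1nn(C)c(Oc2ccc(I)cc2)c1/C=N\CCCCCCOc1cc2oc(=O)cc(C)c2cc1Cl` remains to be measured. Its change from compound 3 is 4-iodophenyl in place of 2,3-difluorophenyl on an oxygen on an aromatic ring. Among the measured compounds shown here, the only measured step that touches the same aromatic oxygen is the one from compound 1 to compound 2, which ended at the limit of > 25000 nM in this assay, at which 1 of the 3 values shown sits, and the iodo group entering here is the same group that entered there. Compound 4 is therefore expected to be a weak inhibitor in this assay, with an estimate of 30000 nM spanning 14000 nM to 70000 nM. The expected step from compound 3 to compound 4 is a 1.3-fold higher number from compound 3 to compound 4 (0.12 log units; within the scatter), and a reported limit rather than a number would be no surprise.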

Compound 4, half-maximal inhibitory concentration: 13300 nM
Compound 4: middle estimate off by 2.3-fold (0.35 log units), on the high side; measured number outside the range, below it.
By their numbers in this assay, from the lowest: compounds 4, 1 and 3 (each within the scatter of the next). At a limit, above all of these: compound 2.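

In this assay the change on this aromatic oxygen stays within the scatter (a 1.7-fold lower number from compound 3 to compound 4 (0.23 log units; within the scatter)) and gives no order between the two compounds. Compound 4 carries 4-iodophenyl and returns a plain number, so this group does not by itself tie a compound to a limit of the assay. Compound 2 carries the same group on a different chain and alone returns a limit rather than a number: the limit of > 25000 nM in this assay, at which 1 of the 4 values shown sits.

The compounds shown leave open whether the chain alone separates compound 2 from compound 4, as no step between them can be read. They also leave open whether an amine or a carboxylic acid on the phenoxy ring, in place of the halogens, would move the number beyond the scatter.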